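Methoxycarbonyl in Place of Pyridin-4-yl: an Estimate

The compounds below may be only part of what the source reports. "The series", "measured", "known", "first", "only" and "open" are said of these compounds alone.

Measured compounds:
compound 1 `CCCCCCCCc1ccc(OCC(=O)Cn2nnc(SC)n2)cc1`: 31 nM
compound 2 `CCCCCCCCc1ccc(OCC(=O)Cn2nnc(-c3ccncc3)n2)cc1`: 24 nM

Both compounds were tested in an assay on microsomes from brain for inhibition of Fatty-acid amide hydrolase 1 (Rattus norvegicus), read by fluorescence and HPLC, with a stated time of 60 min; on this read-out higher numbers stand for weaker inhibition and lower numbers for stronger inhibition. On this read-out compound 1 gives 31 nM and compound 2 gives 24 nM. For the measured compounds named here, compound 2 and compound 1, the only other measured compound, lie within the usual scatter of each other, so neither can be called stronger: the step of a 1.3-fold lower number from compound 1 to compound 2 (0.11 log units; within the scatter) is too small to count as a real difference.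

Compound 3 is `CCCCCCCCc1ccc(OCC(=O)Cn2nnc(C(=O)OC)n2)cc1`. It differs from compound 2 in one place: methoxycarbonyl in place of pyridin-4-yl on an aromatic carbon. Going by the values given here, the only measured step that bears on this change is a 1.3-fold lower number from compound 1 to compound 2 (0.11 log units; within the scatter), which also swapped the group at this same ring carbon and left the number essentially where it was. Among the compounds with values here, there is no measured example of a methoxycarbonyl group at this position, so the expectation rests on that single step alone.

Compound 3 is therefore expected to show no change beyond the scatter, a step of a 1.3-fold higher number from compound 2 to compound 3 (0.10 log units; within the scatter). The estimate for compound 3 in this assay is 30 nM, with a range from 10 nM to 90 nM.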

Compound 3, half-maximal inhibitory concentration: 88 nM
Compound 3: middle estimate off by 2.9-fold (0.47 log units), on the low side, within the range that was stated.
By their numbers in this assay, from the lowest: compounds 2 and 1 (each within the scatter of the next); then compound 3.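

Methoxycarbonyl is the first group at this ring carbon to move the number beyond the scatter, with a 3.7-fold higher number from compound 2 to compound 3 (0.56 log units; beyond the scatter) and a 2.8-fold higher number from compound 1 to compound 3 (0.45 log units; beyond the scatter). Compound 1 and compound 2 alone made the position look indifferent to what sits on it, and compound 3 shows that it is not, although both steps are modest. The loss of a ring cannot be enough to account for the rise: methylsulfanyl also carries no ring, yet compound 1 stays within the scatter of compound 2, which carries pyridin-4-yl.

Nothing available gives a reason for the rise seen with methoxycarbonyl. Still open, on these data alone, is whether the rise follows the carbonyl or the whole methyl ester, and how a carboxylic acid, an amide or a plain methyl group on this ring carbon would compare.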